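A few compounds are considered here, and "the series" means these few. Any claim that something is new, unique, unknown or untested is made for them only; others in the source may bear on it.

In an in vitro ADME assay on microsomes from liver (Rattus norvegicus) for metabolic stability, tested at 1 uM (a higher number here means that the compound lasts longer, a lower number that the compound disappears faster), compound 1 `CN(C)c1ccc(C(=O)N2CCC(NS(=O)(=O)c3cc(S(=O)(=O)c4ccccc4)ccc3C(F)(F)F)CC2)cn1` gives 0.0333 h and compound 2 `CC(C)(O)CCN1CCC(NS(=O)(=O)c2cc(S(=O)(=O)c3ccccc3)ccc2C(F)(F)F)CC1` gives 0.05 h. The step between them is a 1.5-fold higher number from compound 1 to compound 2 (0.18 log units; within the scatter), so the two cannot be ranked. Compound 3 `O=C(CC1CCNCC1)N1CCC(NS(=O)(=O)c2cc(S(=O)(=O)c3ccccc3)ccc2C(F)(F)F)CC1` reads > 0.5 h, which is a limit of the assay and not a number.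

Compound 4 `O=C([C@@H]1CCNC1)N1CCC(NS(=O)(=O)c2cc(S(=O)(=O)c3ccccc3)ccc2C(F)(F)F)CC1` carries (pyrrolidin-3-yl)carbonyl in place of 3-hydroxy-3-methylbutyl on an amine nitrogen in a ring.

Within the data shown here, the nearest precedent is an at least 10-fold higher number from compound 2 to compound 3 (1.00 log units; beyond the scatter), where ((piperidin-4-yl)methyl)carbonyl enters at the same place. Its entering group resembles that of compound 4 in pairing a carbonyl with a non-aromatic nitrogen ring. The step of an at least 15-fold higher number from compound 1 to compound 3 (1.17 log units; beyond the scatter) points the same way. Compound 1 goes against crediting the carbonyl alone, since it also has a carbonyl at that place and still shows a 1.5-fold higher number from compound 1 to compound 2 (0.18 log units; within the scatter). Both steps to compound 3 are large but rest on a limit, and the pyrrolidin-3-yl group has not been tested in this series, so a rise somewhat smaller than those steps is the cautious expectation.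

The expected change is a 6.0-fold higher number from compound 2 to compound 4 (0.78 log units; beyond the scatter). The half-life of compound 4 is estimated at 0.3 h, with an expected range from 0.08 h to 1 h.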

Compound 4, half-life: > 0.5 h
Compound 4 gave a limit, no number (the forecaster's own chance of this, stated with the estimate: 35%); at least 1.6-fold (0.22 log units) between middle value and limit.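

In this assay a second carbonyl-linked, non-aromatic nitrogen ring gives a gain on the amine nitrogen in a ring: an at least 10-fold higher number from compound 2 to compound 4 (1.00 log units; beyond the scatter), so the rise is no longer tied to the ((piperidin-4-yl)methyl)carbonyl group of compound 3 alone. The comparison with the aromatic amide runs the same way, an at least 15-fold higher number from compound 1 to compound 4 (1.17 log units; beyond the scatter), and compound 1 goes against crediting the carbonyl by itself, since it carries a carbonyl at this place too. Compound 4 ends at a limit of the assay and not at a number, so both steps are lower bounds, and pyrrolidin-3-yl in place of (piperidin-4-yl)methyl on a carbonyl carbon gives a step that cannot be read: the limit of > 0.5 h in this assay, at which 2 of the 4 values shown sit.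

From the compounds shown here alone, how far the half-lives of compound 3 and compound 4 extend past that limit stays open, and with it any ranking of the two rings. Also open, going by these compounds, is whether the ring nitrogen matters to the gain, which a cyclopentylcarbonyl group in place of (pyrrolidin-3-yl)carbonyl would address, and whether a methyl on the pyrrolidine nitrogen or the opposite stereocentre would keep it.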